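Bromo to ethylamino on the acetamide chain

The source may hold more compounds than are shown below. What is called first, only, known or untested is meant among the compounds shown, and "the series" means these compounds.

Measured in a functional assay on HCT-8 cells (Homo sapiens) for antiproliferative activity, read by MTT assay, with a stated time of 48 h; on this read-out higher numbers stand for weaker inhibition and lower numbers for stronger inhibition:
- compound 1 `COc1ccc(C(=O)c2ccc(OC)c3c2OC(C)(C)C=C3)c(NC(=O)CBr)c1`: 3250 nM
- compound 2 `COc1ccc(C(=O)c2ccc3c(c2)C=CC(C)(C)O3)c(NC(=O)CO)c1`: 250 nM
- compound 3 `CNCC(=O)Nc1cc(OC)ccc1C(=O)c1ccc2c(c1)C=CC(C)(C)O2`: 1010 nM

Of the three, compound 1 gives the highest number, with compound 3 nearest and compound 2 furthest. Next to be measured is compound 4 `CCNCC(=O)Nc1cc(OC)ccc1C(=O)c1ccc(OC)c2c1OC(C)(C)C=C2`. The change from compound 1 is ethylamino in place of bromo on a saturated chain carbon bound to a carbonyl carbon. For the measured compounds named here, only one measured step bears on it, and only loosely: a 4.0-fold higher number from compound 2 to compound 3 (0.61 log units; beyond the scatter), with methylamino in place of hydroxy on a core that differs from that of compound 1. Going by the values given here, no measured step has bromo leaving. No change beyond the scatter is therefore expected in this assay. The expected step is a 1.6-fold lower number from compound 1 to compound 4 (0.21 log units; within the scatter). For compound 4 the estimated value is 2000 nM, with an expected range of 600 nM to 6500 nM.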

Compound 4, half-maximal inhibitory concentration: 3690 nM
The estimate for compound 4 lay 1.8-fold (0.27 log units) below the measured number; the measured number falls inside the stated range.
By their numbers in this assay, from the lowest: compound 2; then compound 3; then compounds 1 and 4 (each within the scatter of the next).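

On the core of compound 1, ethylamino in place of bromo on a saturated chain carbon bound to a carbonyl carbon gives a 1.1-fold higher number from compound 1 to compound 4 (0.06 log units; within the scatter) in this assay. The earlier amine step, methylamino in place of hydroxy, stood on a different core and went beyond the scatter; here, a bromo group and an amine on this chain read alike. No evidence is available that accounts for this result.

Open, going by these compounds, is how a carboxylic acid or a longer chain would read at this place on the core of compound 1. Also open, on these data alone, is how hydroxy would read there.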